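The compounds below may be only part of what the source reports. "The series", "measured", "known", "first", "only" and "open" are said of these compounds alone.

In a functional assay on MIA PaCa-2 cells (Homo sapiens) for antiproliferative activity, read by MTT assay, with a stated time of 72 h (on this read-out higher numbers stand for weaker inhibition and lower numbers for stronger inhibition), compound 1 (`O=C1O/C(=C\Cn2cnc3cc[nH]c3c2=O)C(OCc2ccccc2)=C1OCc1ccccc1`) is reported only as a limit, > 100000 nM. Compound 2 (`O=C1O/C(=C\Cn2cnc3ncc(Br)c-3c2)C(OCc2ccccc2)=C1OCc1ccccc1`) is also reported only as a limit, > 100000 nM. Among the compounds with values here, compound 2 therefore has no number of its own, and the limit of > 100000 nM in this assay, at which 2 of the 2 values shown sit, covers both values so far. Compound 3 (`O=C1O/C(=C\Cn2cnc3c(Cl)c(F)nc(F)c32)C(OCc2ccccc2)=C1OCc1ccccc1`) differs from compound 2 by a group of 12 heavy atoms (6 carbon, 3 nitrogen, 2 fluorine, 1 chlorine; one five-membered aromatic ring with 2 hetero atoms, one six-membered aromatic ring with 1 hetero atom) in place of a group of 10 heavy atoms (6 carbon, 3 nitrogen, 1 bromine; one five-membered aromatic ring with 1 hetero atom, one six-membered aromatic ring with 2 hetero atoms), on a saturated chain carbon bound to a double-bonded chain carbon. Within the data shown here, the one measured step at this place is a step that the two limits leave unreadable from compound 1 to compound 2. Its size cannot be read, so compound 2 offers no measure of what a new group does here. The data thus support no firm size or direction, though a small gain in inhibition is tentatively expected, and another limit is quite possible. The estimated step is an at least 1.4-fold lower number from compound 2 to compound 3 (0.15 log units; that floor lies within the scatter). For compound 3, the expected half-maximal inhibitory concentration is 70000 nM, with an estimated range from 10000 nM to 150000 nM.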

Compound 3, half-maximal inhibitory concentration: > 100000 nM
Compound 3: a limit, no number; the forecaster's own chance of this, stated with the estimate: 55%; middle value at least 1.4-fold (0.15 log units) from the limit.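

The steps among compound 1, compound 2 and compound 3 cannot be read, as all three are reported only as limits in this assay: the limit of > 100000 nM in this assay, at which 3 of the 3 values shown sit. The compounds shown leave open how far any of these groups, on a saturated chain carbon bound to a double-bonded chain carbon, shifts antiproliferative activity, and in which direction.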